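The compounds below may be only part of what the source reports. "The series", "measured", "known", "first", "only" and "open" are said of these compounds alone.

Measured so far in a functional assay on MCF7 cells (Homo sapiens) for cytotoxicity, read by MTT assay, with a stated time of 72 h; on this read-out lower numbers stand for stronger inhibition and higher numbers for weaker inhibition:
- Compound 1 `COc1cccc(/C=C2\CCC/C(=C\c3cccc(O)c3)C2=O)c1OC`: 8800 nM
- Compound 2 `COc1cccc(/C=C2\CCC/C(=C\c3ccc(O)cc3)C2=O)c1OC`: > 20000 nM, a limit
- Compound 3 `COc1cccc(/C=C2\CCC/C(=C\c3cccc(Cl)c3Cl)C2=O)c1OC`: > 20000 nM, a limit

Compound 3 has no exact number in this assay, only the limit > 20000 nM. Its place is the limit of > 20000 nM in this assay, at which 2 of the 3 values shown sit.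

Compound 4 `COc1cccc(/C=C2\CCC/C(=C\c3ccc(O)c(O)c3)C2=O)c1OC` has 3,4-dihydroxyphenyl in place of 2,3-dichlorophenyl on a double-bonded chain carbon bound to a double-bonded ring carbon.

Within the data shown here, two measured steps bear on this change. One is an at least 2.2-fold higher number from compound 1 to compound 2 (0.35 log units; beyond the scatter), where 4-hydroxyphenyl replaces 3-hydroxyphenyl. The other is an at least 2.2-fold higher number from compound 1 to compound 3 (0.35 log units; beyond the scatter), where 2,3-dichlorophenyl replaces 3-hydroxyphenyl. The third, a step that the two limits leave unreadable from compound 2 to compound 3, adds nothing about size.

Only compound 1 gives an exact number, 8800 nM, so compound 4, which also carries hydroxyl groups, is expected to move toward that value. The expected change, leaning to a lower number, is an at least 2.0-fold lower number from compound 3 to compound 4 (0.30 log units; that floor lies within the scatter). For compound 4 the estimated value is 10000 nM, with an expected range from 3000 nM to 20000 nM.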

Compound 4, half-maximal inhibitory concentration: 4700 nM
Compound 4: the middle estimate sits 2.1-fold (0.33 log units) above what was measured, and the stated range covers the measured number.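

At this place, on a double-bonded chain carbon bound to a double-bonded ring carbon, 3,4-dihydroxyphenyl in place of 2,3-dichlorophenyl gives an at least 4.2-fold lower number from compound 3 to compound 4 (0.62 log units; beyond the scatter) in this assay. Hydroxy in place of hydrogen on an aromatic carbon of the 4-hydroxyphenyl ring gives an at least 4.2-fold lower number from compound 2 to compound 4 (0.62 log units; beyond the scatter), so a single hydroxy on the ring does not fix the outcome here, whereas a 1.9-fold lower number from compound 1 to compound 4 (0.27 log units; within the scatter) leaves those two compounds indistinguishable. Both larger steps give only a minimum size, since compound 2 and compound 3 each stand at a limit of the assay rather than at a number: the limit of > 20000 nM in this assay, at which 2 of the 4 values shown sit.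

On these data alone, how far compound 2 and compound 3 really lie from compound 4 stays open. So does whether an amine or a carboxylic acid at this place would fit the same picture as the hydroxy groups.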